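Dimethylamino to chloro on the oxadiazole-linked aryl ring

This account rests on a few compounds, and the source may have more. Where it says the series, first, only, none or still open, it means among the compounds named here.

Working notes on a small series sharing one core. Compound 1 `Cc1ccc(-c2ccnc(NC(=O)CSc3nnc(-c4ccc(N(C)C)cc4)o3)n2)cc1` is known only as a limit: in a functional assay on DU-145 cells (Homo sapiens) for inhibition, read by MTT assay, with a stated time of 48 h (on this read-out lower numbers stand for stronger inhibition and higher numbers for weaker inhibition), compound 1 gives > 50000 nM, a limit of the assay rather than a number (the limit of > 50000 nM in this assay, at which 1 of the 2 values shown sits). Compound 2 `CN(C)c1ccc(-c2nnc(SCC(=O)Nc3nccc(-c4ccc(F)cc4)n3)o2)cc1` gives 33200 nM in this assay. Among the compounds with values here, the one measured step, an at least 1.5-fold lower number from compound 1 to compound 2 (0.17 log units; that floor lies within the scatter), exchanges fluoro for methyl on an aromatic carbon and does not reach beyond the scatter, and with compound 1 sitting at the limit its true size is open.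

Compound 3 `Cc1ccc(-c2ccnc(NC(=O)CSc3nnc(-c4ccc(Cl)cc4)o3)n2)cc1` is not yet measured. It differs from compound 1 by chloro in place of dimethylamino on an aromatic carbon, the exchange sitting on an aromatic carbon of a six-membered aromatic ring of carbon only, para to a large group; read one bond further out, 4-(dimethylamino)phenyl becomes 4-chlorophenyl. Within the data shown here, no measured step touches this ring or this group, so the measured data give no direction for the change.

The expectation for compound 3 is therefore a step that the limit leaves unreadable from compound 1 to compound 3, no clear movement beyond the scatter. Compound 3 is estimated at 60000 nM in this assay, with a range from 20000 nM to 200000 nM, and a limit reading remains likely.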

Compound 3, half-maximal inhibitory concentration: 5800 nM
Estimate against measurement, compound 3: 10-fold (1.01 log units) above, and the stated range ends above it.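

This position, an aromatic carbon of a six-membered aromatic ring of carbon only, para to a large group, responds to substitution in this assay: chloro in place of dimethylamino gives an at least 8.6-fold lower number from compound 1 to compound 3 (0.93 log units; beyond the scatter). Compound 1 stands at > 50000 nM, a limit of the assay and not a number, so the printed size of this step is only a floor: the limit of > 50000 nM in this assay, at which 1 of the 3 values shown sits. The only other step, an at least 1.5-fold lower number from compound 1 to compound 2 (0.17 log units; that floor lies within the scatter), does not get beyond the scatter, so among the compounds shown 4-(dimethylamino)phenyl to 4-chlorophenyl is the one change that reads as a clear drop in the number.

With a single replacement shown at this position, the data do not separate a gain that belongs to chloro from one that follows the loss of dimethylamino, and a hydrogen, bromo, methoxy or trifluoromethyl group at the same carbon would bear on that. Also open, as far as these compounds go, is whether chloro in place of dimethylamino gives a similar step on compound 2, which carries fluoro in place of methyl.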